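Benzyl for Propargyl on Two Carbamate Cores

The source may report more compounds than this note shows. Statements on the series, on what has been measured and on what is new or still open speak of the compounds shown alone.

Compound 1 `C#CCN1CCCC(OC(=O)Nc2ccc(C(C)C)cc2)C1` and compound 3 `CC(C)c1ccc(NC(=O)OC2CCCN(Cc3ccccc3)C2)cc1` share one core; in an assay on BTI-TN-5B1-4 cells for inhibition of Amine oxidase [flavin-containing] B (Homo sapiens), read by fluorescence and Amplex Red, using microsomes, with a stated time of 15 min (on this read-out higher numbers stand for weaker inhibition and lower numbers for stronger inhibition), compound 1 gives 71800 nM and compound 3 gives 29300 nM. The change between them, (phenyl in place of ethynyl on a saturated chain carbon bound to an amine nitrogen in a ring), produced a 2.5-fold lower number from compound 1 to compound 3 (0.39 log units; beyond the scatter). Compound 2 `C#CCN1CCC(COC(=O)Nc2ccc(C(C)C)cc2)CC1` rests on another core, and the difference between the two cores is not broken down here. In this assay compound 2 gives 316 nM, the lowest of the three numbers and beyond the scatter from both others. Compound 4 `CC(C)c1ccc(NC(=O)OCC2CCN(Cc3ccccc3)CC2)cc1` arises from compound 2 by the same change, (phenyl in place of ethynyl on a saturated chain carbon bound to an amine nitrogen in a ring). Because the same change earlier gave a 2.5-fold lower number from compound 1 to compound 3 (0.39 log units; beyond the scatter), a step of similar size is expected here, a 2.1-fold lower number from compound 2 to compound 4 (0.32 log units; beyond the scatter). Compound 4 is accordingly estimated at 150 nM, within a range from 40 nM to 800 nM.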

Compound 4, half-maximal inhibitory concentration: > 100000 nM
Compound 4 ended at the assay's limit; the forecaster's own chance of this, stated with the estimate: 3%; at least 660-fold (2.82 log units) between middle value and limit.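

On the core of compound 2, the change from propargyl to benzyl gave an at least 310-fold higher number from compound 2 to compound 4 (2.50 log units; beyond the scatter) in this assay, so the modest step seen on the core of compound 1 did not carry over, and the two steps run in opposite directions: the same change on two cores in this assay, a 2.5-fold lower number (0.39 log units; beyond the scatter) from compound 1 to compound 3 and an at least 310-fold higher number (2.50 log units; beyond the scatter) from compound 2 to compound 4, at least 770-fold (2.88 log units) apart, beyond the scatter of two such steps

For compound 4, > 100000 nM is a limit of the assay and not a number: the limit of > 100000 nM in this assay, at which 1 of the 4 values shown sits.

The pair shows that the outcome of this change differed between these two cores, but it does not explain the difference or give a rule for any other core.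

The compounds shown leave open how a methyl group or a phenylethyl chain on the amine nitrogen in a ring would behave on either core.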